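The compounds below may be only part of what the source reports. "The series", "measured", "known", "first", "only" and "open" are said of these compounds alone.

In a functional assay on cells (Cancer cell lines, Homo sapiens) for inhibition (a higher number here means a weaker inhibitor of growth, a lower number a stronger inhibitor of growth), three compounds have been measured so far. Compound 1 (`Cc1cc(-c2nc3sc(C)cn3c2/C=N/NC(=N)N)c(C)s1`) gives 32400 nM, compound 3 (`Cc1cc(-c2nc3sccn3c2/C=N/NC(=N)N)c(C)s1`) gives 32400 nM, and compound 2 (`Cc1cn2c(/C=N/Nc3ccccn3)c(-c3ccc(Cl)c([N+](=O)[O-])c3)nc2s1`) gives 39800 nM. Compound 1 therefore stands level with compound 3, and compound 2 lies within the scatter of both.

Compound 4 (`Cc1cn2c(/C=N/NC(=N)N)c(-c3cccs3)nc2s1`) differs from compound 1 in one place, with thiophen-2-yl in place of 2,5-dimethylthiophen-3-yl on an aromatic carbon. Among the measured compounds shown here, no measured step tests this change directly. For the measured compounds named here, the only measured single-place step, hydrogen in place of methyl on an aromatic carbon, is no change at the digits printed from compound 1 to compound 3 (within the scatter), and it concerns a different place in the molecule. Compound 2, which carries other groups, still gives 39800 nM. On this limited evidence, no step beyond the scatter is expected in this assay. The expected step is a 1.0-fold lower number from compound 1 to compound 4 (0.01 log units; within the scatter). For compound 4, the estimated value is 32000 nM, with an expected range from 16000 nM to 55000 nM.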

Compound 4, concentration for total growth inhibition: 14100 nM
For compound 4 the middle estimate is 2.3-fold (0.36 log units) above the measured one; the measured number lies below the stated range.
By their numbers in this assay, from the lowest: compound 4; then compounds 1, 3 and 2 (each within the scatter of the next).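

In this assay, among the compounds shown here, this place on the shared core is the first to move the number beyond the scatter: thiophen-2-yl in place of 2,5-dimethylthiophen-3-yl gives a 2.3-fold lower number from compound 1 to compound 4 (0.36 log units; beyond the scatter), whereas the one earlier step, at a different place, gave no change at the digits printed from compound 1 to compound 3 (within the scatter). The change alters the attachment point on the thiophene and removes both methyl groups at once, so this single step cannot separate the two. Nothing measured here accounts for the step.

The compounds shown leave open whether a thiophen-3-yl without methyl groups would behave like the thiophen-2-yl of compound 4 or like the 2,5-dimethylthiophen-3-yl of compound 1. They also do not show how a phenyl ring or a single methyl group would fare at this place.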